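Swapping a sec-butyl ether for a thiophenylmethyl ether

A few compounds are considered here, and "the series" means these few. Any claim that something is new, unique, unknown or untested is made for them only; others in the source may bear on it.

Measured compounds:
compound 1, `CCC(C)O[C@@H]1C[C@@H]2[C@H]([C@]1(N)C(=O)O)[C@@]2(F)C(=O)O`: 6.68 nM
compound 2, `N[C@]1(C(=O)O)[C@H]2[C@@H](C[C@H]1OCc1cc(F)cc(F)c1)[C@]2(F)C(=O)O`: 12.4 nM
compound 3, `N[C@]1(C(=O)O)[C@H]2[C@@H](C[C@H]1OCc1cccc(F)c1F)[C@]2(F)C(=O)O`: 4.25 nM

In an assay on CHO cells for binding affinity to metabotropic glutamate receptor 2 (Rattus norvegicus) (on this read-out lower numbers stand for stronger inhibition and higher numbers for weaker inhibition), compound 1 gives 6.68 nM. Its number lies between those of compound 3 and compound 2, and both gaps fall within the usual scatter of repeated measurements, so nothing separates these three on this read-out with confidence. Within the data shown here, the only step that is clearly beyond the scatter runs between the two arylmethyl ethers: a 2.9-fold lower number from compound 2 to compound 3 (0.47 log units; beyond the scatter).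

Compound 4, `N[C@]1(C(=O)O)[C@H]2[C@@H](C[C@H]1OCc1cccs1)[C@]2(F)C(=O)O`, has not yet been measured in this assay. It differs from compound 1 by (thiophen-2-yl)methyl in place of sec-butyl on an oxygen on a saturated carbon. Among the measured compounds shown here, no measured step covers this change directly, since compound 2 and compound 3 both carry a difluorophenyl ring on the chain carbon rather than a thiophene, and the move from sec-butyl to an arylmethyl group is not itself isolated in any pair. What the values of compound 2 and compound 3 do show is that arylmethyl ethers on this oxygen sit on either side of the number of compound 1. Compound 4 is therefore expected to land in the same region, with a 1.0-fold lower number from compound 1 to compound 4 (0.01 log units; within the scatter) amounting to no change beyond the scatter. The estimate for compound 4 is 6.5 nM, with a range from 2.5 nM to 16 nM.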

Compound 4, inhibition constant: 8.79 nM
The estimate for compound 4 lay 1.4-fold (0.13 log units) below the measured number; the range from low to high includes it.
By their numbers in this assay, from the lowest: compounds 3, 1, 4 and 2 (each within the scatter of the next, the first and the last beyond it).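

In this assay, the exchange of sec-butyl for (thiophen-2-yl)methyl on the oxygen can now be read directly (a 1.3-fold higher number from compound 1 to compound 4 (0.12 log units; within the scatter)), and at this position a group with no ring and one carrying a five-membered aromatic ring are not separated by this read-out. The ring on the saturated chain carbon does register in one comparison: thiophen-2-yl is set apart from 2,3-difluorophenyl (a 2.1-fold higher number from compound 3 to compound 4 (0.32 log units; beyond the scatter)) but not from 3,5-difluorophenyl (a 1.4-fold lower number from compound 2 to compound 4 (0.15 log units; within the scatter)), so compound 4 joins compound 1 and compound 2 in showing no step beyond the scatter among themselves, and only compound 3 stands apart from compound 2 and compound 4. Nothing available explains why these rings compare as they do.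

The compounds shown leave open how an unsubstituted phenyl, a thiophen-3-yl or a pyridinyl ring on the chain carbon would compare with thiophen-2-yl and 2,3-difluorophenyl. They also leave open whether a longer chain carrying the thiophene on the same oxygen would stay within the scatter of compound 4.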